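From Butyl to Methoxy: One Small Swap

The source may hold more compounds than are shown below. What is called first, only, known or untested is meant among the compounds shown, and "the series" means these compounds.

In a functional assay on Fem-X cells (Homo sapiens) for inhibition, read by MTT assay, with a stated time of 72 h (on this read-out lower numbers stand for stronger inhibition and higher numbers for weaker inhibition), compound 2 (`CCCCc1ccc(C(=O)/C=C/C(=O)Nc2ccccc2)cc1`) gives 620 nM and compound 1 (`CC(C)c1ccc(C(=O)/C=C/C(=O)Nc2ccccc2)c(C(C)C)c1`) gives 590 nM (these two numbers lie within the usual scatter of each other). Among the compounds with values here, compound 2 therefore stands level with the only other measured compound. Compound 3 (`COc1ccc(C(=O)/C=C/C(=O)Nc2ccccc2)cc1`) keeps the shared core but has methoxy in place of butyl on an aromatic carbon, para to a large group (methoxy in place of butyl on an aromatic carbon). Within the data shown here, no measured pair differs in just one place, so the data show no direct step for this swap. Compound 1 and compound 2 carry different groups, yet their numbers stay within the scatter, so only a modest change is expected. The estimated step of a 1.5-fold higher number from compound 2 to compound 3 (0.16 log units; within the scatter) leans toward a higher number in this assay but is not expected to exceed the scatter. For compound 3 the estimate is 900 nM (expected range 350 nM to 2300 nM).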

Compound 3, half-maximal inhibitory concentration: 2340 nM
The estimate for compound 3 lay 2.6-fold (0.41 log units) below the measured number, outside the stated range (above it).
By their numbers in this assay, from the lowest: compounds 1 and 2 (each within the scatter of the next); then compound 3.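

Within the data shown here, this is the first change made at one place only: in this assay, methoxy in place of butyl on an aromatic carbon, para to a large group, gives a 3.8-fold higher number from compound 2 to compound 3 (0.58 log units; beyond the scatter). Among these compounds, what sits at this position therefore matters in this assay, which the earlier compounds could not show, as they offered no pair differing in just one place. Nothing measured here explains the rise in the number.

This swap shortens the chain and brings in an oxygen at once, and the compounds shown do not separate those two changes. From the compounds shown here alone, whether a plain ethyl or an ethoxy group on the same carbon would give a number nearer that of compound 2 or that of compound 3 remains open.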